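This account rests on a few compounds, and the source may have more. Where it says the series, first, only, none or still open, it means among the compounds named here.

In a functional assay on HL-60 cells (Homo sapiens) for antiproliferative activity, with a stated time of 72 h (a higher number here means a weaker inhibitor, a lower number a stronger inhibitor), two compounds have been measured so far

Compound 1 `OC[C@H]1O[C@@H](n2cnc3c(NCc4ccc(Cl)cc4)ncnc32)[C@H](O)[C@@H]1O` gives 1700 nM
Compound 2 `COc1ccc(CNc2ncnc3c2ncn3[C@@H]2O[C@H](CO)[C@@H](O)[C@H]2O)c(OC)c1` gives 39000 nM

Within the data shown here, compound 2 holds the higher of these two numbers, and its only neighbour is compound 1, with a 23-fold higher number from compound 1 to compound 2 (1.36 log units; beyond the scatter) as the single measured step.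

Next is compound 3 `OC[C@H]1O[C@@H](n2cnc3c(NCc4ccc(F)c(Cl)c4)ncnc32)[C@H](O)[C@@H]1O`, still unmeasured. The structural change is 3-chloro-4-fluorophenyl in place of 2,4-dimethoxyphenyl on a saturated chain carbon bound to a nitrogen on an aromatic ring in the form of 3-chloro-4-fluorophenyl in place of 2,4-dimethoxyphenyl on a saturated chain carbon bound to a nitrogen on an aromatic ring.

Among the measured compounds shown here, the one step that bears on this change is a 23-fold higher number from compound 1 to compound 2 (1.36 log units; beyond the scatter) and it is large, at the same place. Compound 3 gives up the 2,4-dimethoxyphenyl and, like the 4-chlorophenyl of compound 1, its new group holds chlorine and no oxygen. For the measured compounds named here, no measured compound shows what the added fluorine does, and one step is thin support. A large move to a lower number in this assay is nevertheless expected, undoing most of that step. The expected size is a 20-fold lower number from compound 2 to compound 3 (1.29 log units; beyond the scatter) as an estimate. For compound 3 the estimated value is 2000 nM with an expected range from 600 nM to 8000 nM for the measurement.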

Compound 3, half-maximal inhibitory concentration: 3500 nM
Beside the measured number, compound 3's estimate is 1.8-fold (0.24 log units) below it; the range from low to high includes it.
By their numbers in this assay, from the lowest: compound 1; then compound 3; then compound 2.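

In this assay, 3-chloro-4-fluorophenyl in place of 2,4-dimethoxyphenyl on a saturated chain carbon bound to a nitrogen on an aromatic ring gives an 11-fold lower number from compound 2 to compound 3 (1.05 log units; beyond the scatter) in this series, so the high number of compound 2 now stands apart from two chlorine-bearing, oxygen-free groups and not from compound 1 alone. Set against the 4-chlorophenyl, the 3-chloro-4-fluorophenyl gives a 2.1-fold higher number from compound 1 to compound 3 (0.31 log units; beyond the scatter) as a modest step beyond the scatter, which shows that this position can take a change of halogen pattern at a far smaller cost than the change to 2,4-dimethoxyphenyl. Nothing at hand explains either step.

Among these compounds, with only three compounds, the series does not separate the role of the two methoxy groups, nor does it show whether chlorine, fluorine or the mere absence of oxygen tracks with the lower numbers. A 4-methoxyphenyl, an unsubstituted phenyl or a 4-fluorophenyl at this place would address those questions, and an aminomethyl or carboxylic acid group on the ring remains an open extension.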